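The source may report more compounds than this note shows. Statements on the series, on what has been measured and on what is new or still open speak of the compounds shown alone.

Of the compounds shown here, three have been measured in an assay on CHO cells for displacement of a labelled ligand from melatonin receptor type 1A (Homo sapiens), with a stated time of 120 min; a lower number here means a stronger inhibitor, a higher number a weaker inhibitor. Compound 1 `CCC(=O)NCCC1CCc2ccccc2N1Cc1ccccc1` gives 326 nM, compound 2 `CCNC(=O)NCC1CCc2c(cccc2OC)N1` gives 480 nM, and compound 3 `CCNC(=O)NCC1CCc2ccccc2N1` gives 115 nM. Compound 3 stands lowest of the three: its steps to compound 1 and to compound 2 are both beyond the scatter, so it is the strongest inhibitor measured here. Within the data shown here, the one single-point step known is a 4.2-fold lower number from compound 2 to compound 3 (0.62 log units; beyond the scatter), which concerns the aromatic methoxy and not the side chain.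

Compound 4 `CCC(=O)NCC1CCc2ccccc2N1` differs from compound 3 in one place: ethyl in place of ethylamino on a carbonyl carbon, that is, ethylcarbamoyl to propanoyl. Among the measured compounds shown here, no measured step bears directly on this change. Compound 1 carries a propanoyl group but also differs from compound 3 elsewhere, so its value and that of compound 3 only show that both lie in a similar range. The step to compound 4 in this assay is therefore expected to be a 1.3-fold higher number from compound 3 to compound 4 (0.12 log units; within the scatter), not clearly beyond the scatter. Compound 4 is estimated at 150 nM, in a range from 50 nM to 500 nM.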

Compound 4, inhibition constant: 13 nM
Compound 4: the middle estimate sits 12-fold (1.06 log units) above what was measured, and the stated range ends above it.
By their numbers in this assay, from the lowest: compound 4; then compound 3; then compounds 1 and 2 (each within the scatter of the next).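

In this assay, among these compounds, the carbonyl carbon of the side chain proves to be a sensitive place: ethyl in place of ethylamino gives an 8.8-fold lower number from compound 3 to compound 4 (0.95 log units; beyond the scatter), whereas the only earlier single-change step concerned the aromatic methoxy. The ethylamino group that leaves carries a nitrogen and a hydrogen-bond donor, and the ethyl that enters carries neither, so the lower number comes with the loss of both, and this one step cannot separate them. Nothing available explains why the number falls.

Going by these compounds, it remains open whether a shorter group such as methyl or a longer chain such as propyl on this carbonyl carbon would keep a number as low as that of compound 4. On these data alone, it is also open whether a methoxy on the aromatic ring would change the number as much with propanoyl as it does with ethylcarbamoyl.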